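Hydroxamic Acid in Place of the Methoxy Chain

This account rests on a few compounds, and the source may have more. Where it says the series, first, only, none or still open, it means among the compounds named here.

In an in vitro assay on BHK cells for inhibition of Glucagon receptor (Homo sapiens) (a higher number here means a weaker inhibitor, a lower number a stronger inhibitor), compound 1 `O=C(O)CCNC(=O)c1ccc(CN(C(=O)Nc2ccc(OC(F)(F)F)cc2)C2CCC3(CC2)OCCO3)cc1` gives 1210 nM. Compound 2 `COCCCNC(=O)c1ccc(CN(C(=O)Nc2ccc(OC(F)(F)F)cc2)C2CCC(C(C)(C)C)CC2)cc1` reaches only the limit of this assay, > 10000 nM, so its position is known just as a limit (the limit of > 10000 nM in this assay, at which 1 of the 2 values shown sits). Compound 3 `CC(C)(C)C1CCC(N(Cc2ccc(C(=O)NCC(=O)NO)cc2)C(=O)Nc2ccc(OC(F)(F)F)cc2)CC1` differs from compound 2 by hydroxycarbamoyl in place of 2-methoxyethyl on a saturated chain carbon bound to an amide-type nitrogen. With compound 2 known only as a limit, the size of the step cannot be fixed; a gain in potency beyond the scatter is expected, though a further limit remains possible. For compound 3 an inhibitory concentration of 5000 nM is estimated, between 1500 nM and 20000 nM, meaning an expected step of an at least 2.0-fold lower number from compound 2 to compound 3 (0.30 log units; that floor lies within the scatter).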

Compound 3, half-maximal inhibitory concentration: 2960 nM
The estimate for compound 3 lay 1.7-fold (0.23 log units) above the measured number; the range from low to high includes it.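

In this assay, this position proves responsive: hydroxycarbamoyl in place of 2-methoxyethyl on a saturated chain carbon bound to an amide-type nitrogen gives an at least 3.3-fold lower number from compound 2 to compound 3 (0.52 log units; beyond the scatter). This step lies beyond the scatter, and it gives the series a measurable number where compound 2 had none. Compound 2 stands only at a limit, so the step is a floor and its full size is unknown: the limit of > 10000 nM in this assay, at which 1 of the 3 values shown sits.

On these data alone, it remains open whether the hydroxycarbamoyl group itself is needed here, or whether a primary amine or a longer chain ending in hydroxycarbamoyl would serve equally well.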